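This account rests on a few compounds, and the source may have more. Where it says the series, first, only, none or still open, it means among the compounds named here.

In a functional assay on HCT-116 cells (Homo sapiens) for inhibition, read by MTT assay, with a stated time of 48 h (a higher number here means a weaker inhibitor, a lower number a stronger inhibitor), compound 1 (`COc1ccc(N(C)c2nc(C)nc3ccccc23)cc1C(=O)OCCC[Se]C#N`) gives 720 nM and compound 2 (`COc1ccc(N(C)c2nc(C)nc3ccccc23)cc1C(=O)OCCCC[Se]C#N`) gives 662 nM with no separation beyond the scatter. Compound 3 (`COc1ccc(N(C)c2nc(C)nc3ccccc23)cc1[Se]C#N`) gives 34 nM as the lowest number of the three and is the strongest inhibitor so far. Compound 4 (`COc1ccc(N(C)c2nc(C)nc3ccccc23)cc1C[Se]C#N`) is not yet measured. It differs from compound 3 by a group of 4 heavy atoms (2 carbon, 1 nitrogen, 1 selenium; no ring) in place of a group of 3 heavy atoms (1 carbon, 1 nitrogen, 1 selenium; no ring), on an aromatic carbon on an aromatic carbon.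

Among the measured compounds shown here, three measured steps bear on this change. The step of a 1.1-fold lower number from compound 1 to compound 2 (0.04 log units; within the scatter) also adds to a selenium-bearing group, and it stays within the scatter, but it sits on a saturated chain carbon and not on an aromatic one. The steps of a 21-fold lower number from compound 1 to compound 3 (1.33 log units; beyond the scatter) and a 19-fold lower number from compound 2 to compound 3 (1.29 log units; beyond the scatter) are both large and take place on the aromatic carbon, but each involves a much bigger group than the one entering here. For the measured compounds named here, no measured compound carries the group of compound 4 on this carbon, so the transfer is uncertain. A moderate step toward a weaker inhibitor is expected, smaller than those two large steps. The expected change is a 2.9-fold higher number from compound 3 to compound 4 (0.47 log units; beyond the scatter) in this assay on this reading. For compound 4 the estimated value is 100 nM with an expected range from 30 nM to 400 nM at this stage.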

Compound 4, half-maximal inhibitory concentration: 113 nM
Compound 4: the middle estimate sits 1.1-fold (0.05 log units) below what was measured, and the stated range covers the measured number.
By their numbers in this assay, from the lowest: compound 3; then compound 4; then compounds 2 and 1 (each within the scatter of the next).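

In this assay, the aromatic carbon ortho to a methoxy group responds to even a small enlargement of the selenium-bearing group: here the step is a 3.3-fold higher number from compound 3 to compound 4 (0.52 log units; beyond the scatter) and lies beyond the scatter, whereas the enlargement on the saturated chain carbon, a 1.1-fold lower number from compound 1 to compound 2 (0.04 log units; within the scatter), stayed within it. The result also fills the gap between the smallest and largest groups on this carbon, with a 5.9-fold lower number from compound 2 to compound 4 (0.77 log units; beyond the scatter) and a 6.4-fold lower number from compound 1 to compound 4 (0.80 log units; beyond the scatter), so the number rises with group size across compound 3, compound 4 and the larger groups, although compound 1 and compound 2 go against a continued rise by staying within the scatter of each other. No available evidence explains the difference at this position.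

The compounds shown leave open whether a longer chain without the carbonyl group would continue the rise or level off as in compound 1 and compound 2. They also leave open how a thiocyanate or a plain nitrile on the same aromatic carbon would compare with the selenium-bearing groups.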